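Aryl change on the shared core: notes toward compound 4

A few compounds are considered here, and "the series" means these few. Any claim that something is new, unique, unknown or untested is made for them only; others in the source may bear on it.

Among the measured compounds shown here, in a functional assay on MCF7 cells (Homo sapiens) for antiproliferative activity, read by CCK-8 assay, with a stated time of 48 h (on this read-out higher numbers stand for weaker inhibition and lower numbers for stronger inhibition), compound 3 `Cc1cc(Nc2cc(N3CCN(C)CC3)nc(Nc3ccc(F)c(Cl)c3)n2)n[nH]1` gives 213 nM, the lowest of the three numbers so far. Compound 2 `Cc1cc(Nc2cc(N3CCN(C)CC3)nc(Nc3ccc(Cl)c(F)c3)n2)n[nH]1` gives 818 nM, and compound 1 `COc1ccc(Nc2nc(Nc3cc(C)[nH]n3)cc(N3CCN(C)CC3)n2)cc1OC` gives 6540 nM.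

The next compound is compound 4 `Cc1cc(Nc2cc(N3CCN(C)CC3)nc(Nc3cccc(F)c3)n2)n[nH]1`. The change is 3-fluorophenyl in place of 3-chloro-4-fluorophenyl on a nitrogen on an aromatic ring, with 3-fluorophenyl in place of 3-chloro-4-fluorophenyl on a nitrogen on an aromatic ring. For the measured compounds named here, no measured compound carries 3-fluorophenyl, so the evidence is indirect.

The closest measured step is a 3.8-fold lower number from compound 2 to compound 3 (0.58 log units; beyond the scatter), which shows that a change among halogen-bearing aryl groups alone can exceed the scatter. The steps of an 8.0-fold lower number from compound 1 to compound 2 (0.90 log units; beyond the scatter) and a 31-fold lower number from compound 1 to compound 3 (1.49 log units; beyond the scatter) show that this aryl position can also produce larger shifts. Both measured departures from 3-chloro-4-fluorophenyl give higher numbers, so a modest rise is expected here.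

The expected step is a 3.1-fold higher number from compound 3 to compound 4 (0.48 log units; beyond the scatter), towards weaker inhibition in this assay.

Compound 4 is estimated at 650 nM, with an expected range of 230 nM to 2000 nM.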

Compound 4, half-maximal inhibitory concentration: 1260 nM
Compound 4: middle estimate off by 1.9-fold (0.29 log units), on the low side; measured number inside the range.
By their numbers in this assay, from the lowest: compound 3; then compounds 2 and 4 (each within the scatter of the next); then compound 1.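

In this assay, 3-fluorophenyl in place of 3-chloro-4-fluorophenyl gives a 5.9-fold higher number from compound 3 to compound 4 (0.77 log units; beyond the scatter), so the low number of compound 3 depends on more than the fluoro group that the two aryl groups share. Hydrogen in place of chloro on an aromatic carbon gives a 1.5-fold higher number from compound 2 to compound 4 (0.19 log units; within the scatter), so on 4-chloro-3-fluorophenyl the chloro group makes no difference that can be told from the scatter, whereas the 3-chloro-4-fluorophenyl arrangement stands apart from both. The 3-fluorophenyl group still gives a 5.2-fold lower number from compound 1 to compound 4 (0.72 log units; beyond the scatter), so most of the gain over 3,4-dimethoxyphenyl remains without any chloro group.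

Nothing available gives a reason for these shifts. Open, from the compounds shown here alone, is how 3-chlorophenyl, unsubstituted phenyl, or a phenyl ring carrying an amine or a carboxylic acid would read.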